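Cyclobutyl to cyclohexyl on the amine of the shared core

The source may report more compounds than this note shows. Statements on the series, on what has been measured and on what is new or still open speak of the compounds shown alone.

Measured compounds:
compound 1, `N#Cc1cnc(NCc2cnccc2C(F)(F)F)cc1N[C@H]1C[C@H](O)C1` — 900 nM
compound 2, `N#Cc1cnc(NCc2ccccc2C(F)(F)F)cc1N[C@H]1CC[C@@H](O)CC1` — 140 nM

In an assay on isolated protein for inhibition of protein kinase C theta type (Homo sapiens), read by TR-FRET, with a stated time of 2 h (a higher number here means a weaker inhibitor, a lower number a stronger inhibitor), compound 1 gives 900 nM, the highest of the two numbers, and so the weaker inhibitor of the pair. Its nearest neighbour is compound 2, which in this assay gives 140 nM; the gap between the two lies beyond the usual scatter. Among the compounds with values here, no step between compounds that differ in one place is available, so only the two values themselves speak.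

Compound 3, `CO[C@H]1CC[C@@H](Nc2cc(NCc3cnccc3C(F)(F)F)ncc2C#N)CC1`, has not yet been measured in this assay. Against compound 1 its change is 4-methoxycyclohexyl in place of 3-hydroxycyclobutyl on a nitrogen on an aromatic ring. A sizable group enters where a small one leaves, on a nitrogen on an aromatic ring whose other neighbour is aromatic carbon, and the hydrogen-bond donor of the 3-hydroxycyclobutyl is gone.

Within the data shown here, with no measured step to lean on, the expectation for compound 3 is a moderate drop in number beyond the scatter, toward the region occupied by compound 2, giving an estimated 2.6-fold lower number from compound 1 to compound 3 (0.41 log units; beyond the scatter). For compound 3 the estimated value in this assay is 350 nM, with an expected range from 100 nM to 1200 nM.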

Compound 3, half-maximal inhibitory concentration: 58 nM
For compound 3 the middle estimate is 6.0-fold (0.78 log units) above the measured one; measured number outside the range, below it.
By their numbers in this assay, from the lowest: compound 3; then compound 2; then compound 1.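

In this assay, 4-methoxycyclohexyl in place of 3-hydroxycyclobutyl on a nitrogen on an aromatic ring gives a 16-fold lower number from compound 1 to compound 3 (1.19 log units; beyond the scatter), so this position tolerates the larger group on the shared core and the change brings a large gain. The hydrogen-bond donor of the 3-hydroxycyclobutyl is gone in compound 3, which still gives 58 nM, so a donor in this group is not required for a value of this size. No measurement is available that bears on the cause of this step.

The step changes ring size, the group on the oxygen and the donor count all at once, and the compounds shown cannot divide it among these three changes; 4-hydroxycyclohexyl and 3-methoxycyclobutyl on the core of compound 1 would separate them. Also open, from the compounds shown here alone, is whether the oxygen contributes at all, which plain cyclohexyl in place of 4-methoxycyclohexyl would address, and whether a 4-aminocyclohexyl group is accepted on the same nitrogen.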